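The source may hold more compounds than are shown below. What is called first, only, known or untested is meant among the compounds shown, and "the series" means these compounds.

Measured so far in a functional assay on HeLa cells (Homo sapiens) for antiproliferative activity, read by MTT assay, with a stated time of 48 h; on this read-out lower numbers stand for stronger inhibition and higher numbers for weaker inhibition:
- compound 1 `COc1ccc(N(C)c2ccnc(Cl)n2)cc1O`: 96 nM
- compound 2 `COc1ccc(N(C)c2ccnc(Cl)n2)cc1OCCCBr`: 307 nM
- compound 3 `COc1ccc(N(C)c2cc(C)nc(C)n2)cc1`: 322 nM

In this assay, compound 3 gives 322 nM, level within the scatter with compound 2 at 307 nM. Compound 1 shows the lower number, 96 nM, but it differs from compound 3 in more than one place, so that gap cannot be pinned on any single change.

The next structure, compound 4 `COc1ccc(N(C)c2cc(C)nc(C)n2)cc1[N+](=O)[O-]`, is compound 3 with nitro in place of hydrogen on an aromatic carbon, ortho to a methoxy group and meta to a large group: nitro in place of hydrogen on an aromatic carbon.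

Among the measured compounds shown here, no measured step installs a nitro group. The closest evidence is a 3.2-fold higher number from compound 1 to compound 2 (0.50 log units; beyond the scatter), a modest step that also changes a group ortho to a methoxy group. That step swaps a different group on an oxygen, so it gives a rough size for such a change but no direction for this one. The data therefore favour no direction, and a shift beyond the scatter cannot be predicted.

The expected change is a 1.1-fold lower number from compound 3 to compound 4 (0.03 log units; within the scatter), a step that stays within the scatter, though with real uncertainty. For compound 4 the estimated value is 300 nM, with an expected range from 90 nM to 1000 nM.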

Compound 4, half-maximal inhibitory concentration: 3720 nM
The estimate for compound 4 lay 12-fold (1.09 log units) below the measured number; measured number outside the range, above it.
By their numbers in this assay, from the lowest: compound 1; then compounds 2 and 3 (each within the scatter of the next); then compound 4.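

In this assay, the aromatic carbon ortho to a methoxy group and meta to a large group proves far from indifferent to substitution: putting nitro in place of hydrogen there gives a 12-fold higher number from compound 3 to compound 4 (1.06 log units; beyond the scatter), a large step towards weaker inhibition. Among the compounds shown here, the only earlier single-place step, a 3.2-fold higher number from compound 1 to compound 2 (0.50 log units; beyond the scatter), was modest and involved a change on an oxygen, so this is the first sign that a change made directly on an aromatic carbon can move the number so much. Nothing in the available data bears on why this step is so large.

The compounds shown leave open whether the step belongs to nitro in particular or would follow from almost any replacement of hydrogen on this carbon. An amine or a carboxylic acid on the same carbon, compared directly with compound 3, would help to separate those two readings.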